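A few compounds are considered here, and "the series" means these few. Any claim that something is new, unique, unknown or untested is made for them only; others in the source may bear on it.

Notes on the series

Three members of the series carry the shared core of compound 1 `Cc1cc(C2=NN(c3ccc(S(C)(=O)=O)cc3)C(=O)CC2)ccc1O` and differ only in the aryl group on a carbon with a double bond to nitrogen. In a functional assay on the whole organism (strain Wistar) for inhibition, with Rattus norvegicus as the target, read by paw edema, with stated times of 30 min and 3 h, at a dose of 0.05 mmol/kg by the oral route (on this read-out lower numbers stand for less inhibition and higher numbers for more inhibition at the one dose given (going by the name of the read-out)), compound 1 gives 26.6%. Compound 2 `Cc1cc(O)ccc1C1=NN(c2ccc(S(C)(=O)=O)cc2)C(=O)CC1` gives 33.3% in this assay, and the step of a number 6.7 percentage points higher from compound 1 to compound 2 (within the scatter) is within the scatter. Compound 3 `CCc1ccc(C2=NN(c3ccc(S(C)(=O)=O)cc3)C(=O)CC2)cc1` gives 46.7% in this assay and stands highest of the three; the steps of a number 20.1 percentage points higher from compound 1 to compound 3 (beyond the scatter) and a number 13.4 percentage points higher from compound 2 to compound 3 (beyond the scatter) both lie beyond the scatter, so compound 3 has the highest number of the measured set.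

Compound 4 `CS(=O)(=O)c1ccc(N2N=C(c3ccc(Cl)c(Cl)c3)CCC2=O)cc1` is not yet measured. The change from compound 3 is 3,4-dichlorophenyl in place of 4-ethylphenyl on a carbon with a double bond to nitrogen. Among the compounds with values here, no measured step bears directly on this exchange: the two steps that end at compound 3 both replace a hydroxy-methylphenyl group with 4-ethylphenyl, whereas here an aryl group without hydroxy or methyl is exchanged for another such group. The measured steps only show that the aryl group at this position can shift the read-out by a modest amount. Within the data shown here, with no directly comparable step, no change beyond the scatter in this assay is expected, and the estimate for compound 4 is 48%, within 32% to 62%, an expected step of a number 1.3 percentage points higher from compound 3 to compound 4 (within the scatter) from compound 3.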

Compound 4, a percentage reported as inhibition, in the whole organism at one dose (the size of the read-out at that dose, not a potency): 26.6%
Estimate against measurement, compound 4: 21.4 percentage points above, outside the stated range (below it).
By their numbers in this assay, from the lowest: compounds 1, 4 and 2 (each within the scatter of the next); then compound 3.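

In this assay, the exchange of one aryl group without hydroxy or methyl for another, with the same heavy-atom count and no hydrogen-bond donors or acceptors on either group, still gives a number 20.1 percentage points lower from compound 3 to compound 4 (beyond the scatter), so this position responds beyond the scatter even when those counts stay the same. The 3,4-dichlorophenyl group does not separate from the two hydroxy-methylphenyl groups, with a number 6.7 percentage points lower from compound 2 to compound 4 (within the scatter) and no change at the digits printed from compound 1 to compound 4 (within the scatter), which leaves compound 3 as the only one of the four whose steps to all the others lie beyond the scatter. Nothing available bears on the reason for this difference between the 4-ethylphenyl and 3,4-dichlorophenyl groups.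

The compounds shown leave open whether the higher number of compound 3 is specific to the ethyl group or would persist with a longer chain such as propyl or butyl on the aryl ring. They also leave open how an amine or a carboxylic acid on that ring would read in this assay, and how any of these aryl groups would compare at other doses.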